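Swapping Trifluoromethyl for a Chloropyridinyloxy Group

The source may report more compounds than this note shows. Statements on the series, on what has been measured and on what is new or still open speak of the compounds shown alone.

compound 1 `Cc1cc(OC(C)C)c(S(C)(=O)=O)cc1C(=O)N=C(N)N` — 19 nM
compound 2 `Cc1cc(C(F)(F)F)c(S(C)(=O)=O)cc1C(=O)N=C(N)N` — 37 nM

Of the compounds shown here, two sharing one core have been measured in a functional assay for inhibition of sodium/hydrogen exchanger (Oryctolagus cuniculus); on this read-out higher numbers stand for weaker inhibition and lower numbers for stronger inhibition. Among the measured compounds shown here, compound 2 gives 37 nM, the higher of the two numbers, while compound 1 gives 19 nM; the only measured step, a 1.9-fold higher number from compound 1 to compound 2 (0.29 log units; within the scatter), lies within the scatter, so the two cannot be told apart.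

Compound 3 `Cc1cc(Oc2cncc(Cl)c2)c(S(C)(=O)=O)cc1C(=O)N=C(N)N` is the next step from compound 2: (5-chloropyridin-3-yl)oxy in place of trifluoromethyl on an aromatic carbon. The step from compound 1 to compound 2 bears on this change, since it also replaced a group at that carbon, and it was small. For the measured compounds named here, the isopropoxy of compound 1 and the entering (5-chloropyridin-3-yl)oxy both attach through an oxygen, which points toward a number near that of compound 1, but no measured step covers a pyridine ring here.

Compound 3 is therefore expected to give about 25 nM, with a range from 8 nM to 80 nM, and the estimated 1.5-fold lower number from compound 2 to compound 3 (0.17 log units; within the scatter) stays within the scatter.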

Compound 3, half-maximal inhibitory concentration: 14 nM
Estimate against measurement, compound 3: 1.8-fold (0.25 log units) above, and the stated range covers the measured number.
By their numbers in this assay, from the lowest: compounds 3, 1 and 2 (each within the scatter of the next, the first and the last beyond it).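

In this assay, among the compounds shown here, the carbon ortho to the methylsulfonyl group accepts a much larger group than trifluoromethyl: (5-chloropyridin-3-yl)oxy, with 8 heavy atoms against 4, gives a 2.6-fold lower number from compound 2 to compound 3 (0.42 log units; beyond the scatter) and is the first change to move the number beyond the scatter. Among the groups attached through oxygen, the identity of the group on that oxygen has not yet been shown to matter, as 5-chloropyridin-3-yl in place of isopropyl gives a 1.4-fold lower number from compound 1 to compound 3 (0.13 log units; within the scatter) and leaves compound 1 and compound 3 indistinguishable. There is no independent evidence here to explain the step from trifluoromethyl.

As far as these compounds go, it remains open what the chlorine and the ring nitrogen each contribute, a question that a plain phenoxy group or an unsubstituted pyridin-3-yloxy group at this carbon could address. From the compounds shown here alone, it is also open whether the oxygen link itself matters, which an amine link to the same ring could test.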